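The compounds below may be only part of what the source reports. "The series", "measured", "known", "first", "only" and "open" are said of these compounds alone.

Measured in a functional assay on U-266 cells (Homo sapiens) for antiproliferative activity, read by MTT assay, with a stated time of 72 h; a higher number here means a weaker inhibitor, a lower number a stronger inhibitor:
- compound 1 `N#C/C(=C\c1cccc(Br)n1)C(=O)N[C@@H](CO)c1ccccc1`: 3500 nM
- compound 2 `C[C@H](NC(=O)/C(C#N)=C/c1cccc(Br)n1)c1ccccc1F`: 2000 nM
- compound 3 `CCC[C@H](NC(=O)/C(C#N)=C/c1ccc(O)c([N+](=O)[O-])c1)c1ccccc1`: 9300 nM

Compound 1, at 3500 nM, holds the second highest of these three numbers. Its gap to compound 2 lies within the usual scatter, so the two cannot be told apart. Compound 3 has a higher number than compound 1, and that gap goes beyond the scatter.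

The next compound, compound 4 `CC(=O)OC[C@H](NC(=O)/C(C#N)=C/c1cccc(Br)n1)c1ccccc1`, changes compound 1 in one place: acetyl in place of hydrogen on an oxygen on a saturated carbon. This puts acetyl in place of hydrogen on an oxygen on a saturated carbon, turning hydroxymethyl into acetoxymethyl.

Among the compounds with values here, no pair of measured compounds shows this change, so there is no direct precedent for it. The measured numbers stay fairly close together, with even compound 3 at 9300 nM, which argues against expecting a large move in this assay. The expected result is a 1.3-fold lower number from compound 1 to compound 4 (0.10 log units; within the scatter), a small move towards a lower number that stays within the scatter. For compound 4 the estimated value is 2800 nM, with an expected range of 1000 nM to 8000 nM.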

Compound 4, half-maximal inhibitory concentration: 2800 nM
Beside the measured number, compound 4's estimate shows no gap at the digits printed; measured number inside the range.
By their numbers in this assay, from the lowest: compounds 2, 4 and 1 (each within the scatter of the next); then compound 3.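

Acetyl in place of hydrogen on this oxygen gives the first single-place comparison in the set, and in this assay it reads as a 1.3-fold lower number from compound 1 to compound 4 (0.10 log units; within the scatter), so compound 1 and compound 4 cannot be told apart. At this position, then, the hydroxymethyl can become acetoxymethyl, a larger group that carries no hydrogen-bond donor, with no measurable shift in the number. Nothing available here gives a reason for this result.

The compounds shown leave open whether a smaller group on the same oxygen, such as methyl, or a longer acyl chain, such as hexanoyl, would also leave the number in place, and whether an amine in place of the hydroxy would do so. This single pair also cannot show whether the same change behaves alike on a different core.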